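Chloro to trifluoromethyl on the aryl ring of compound 3

The source may hold more compounds than are shown below. What is called first, only, known or untested is meant among the compounds shown, and "the series" means these compounds.

Of the compounds shown here, three have been measured in an assay on CHO cells for agonist activity at Free fatty acid receptor 1 (Homo sapiens), read by FLIPR; a higher number here means that more compound is needed for the effect, a lower number that less compound is needed. Compound 1 `Cc1nc(-c2cccc(F)c2)sc1COc1ccc(OCC(=O)O)c(F)c1` gives 185 nM, and compound 2 `Cc1ccc(-c2nc(C)c(COc3ccc(OCC(=O)O)c(F)c3)s2)cc1` gives 156 nM. Within the data shown here, the single one-place step among them, a 1.2-fold lower number from compound 1 to compound 2 (0.07 log units; within the scatter), changes the substituent on the aryl ring and stays within the scatter. Compound 3 `Cc1nc(-c2ccc(Cl)cc2)sc1COc1ccc2c(c1)OCC2CC(=O)O` gives 105 nM in this assay; it has the lowest of the three numbers, but its gaps to compound 2 and to compound 1 both lie within the scatter, so no order among the three can be claimed.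

Compound 4 `Cc1nc(-c2ccc(C(F)(F)F)cc2)sc1COc1ccc2c(c1)OCC2CC(=O)O` differs from compound 3 in one place: trifluoromethyl in place of chloro on an aromatic carbon. Among the measured compounds shown here, no measured step covers this exact exchange. For the measured compounds named here, the only step available, from compound 1 to compound 2, also alters the substituent on the aryl ring, and its size was within the scatter; that is the sole guide here, and it points to no change beyond the scatter in this assay.

On that basis compound 4 is expected to give about 110 nM, with a range from 45 nM to 280 nM, which corresponds to an expected step of a 1.0-fold higher number from compound 3 to compound 4 (0.02 log units; within the scatter).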

Compound 4, half-maximal effective concentration: 113 nM
Compound 4: middle estimate off by 1.0-fold (0.01 log units), on the low side; the measured number falls inside the stated range.
By their numbers in this assay, from the lowest: compounds 3, 4, 2 and 1 (each within the scatter of the next).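

In this assay, among these compounds, the exchange on the aromatic carbon para to a large group gives a 1.1-fold higher number from compound 3 to compound 4 (0.03 log units; within the scatter) and is the first measured step to start from the 4-chlorophenyl group of compound 3. Replacing chloro, with 1 heavy atom, by trifluoromethyl, with 4 heavy atoms, thus leaves the number within the scatter on this core, so this place accepts both groups without a measurable difference in this assay; the earlier one-place step, from 3-fluorophenyl to 4-methylphenyl, was read on a different core and could not show this. The data shown offer no measurement that would explain why the two groups read alike and the result stands as an observation only.

Going by these compounds, whether a methoxy group, a nitrile or an amine at this same place would also stay within the scatter remains open, since both groups compared here carry no hydrogen-bond donors or acceptors. Also open is whether the same exchange would read alike on the core of compound 1 or compound 2, where no such pair is shown.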